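Triflate to Fluorophenyl at the Same Aromatic Carbon

The compounds below may be only part of what the source reports. "The series", "measured", "known", "first", "only" and "open" are said of these compounds alone.

Compound 1 `C=C[C@@](C)(/C=C/c1ccc(OS(=O)(=O)C(F)(F)F)cc1)CCC=C(C)C`: > 43400 nM in a functional assay on NALM-6 cells (Homo sapiens) for cytotoxicity, with a stated time of 72 h (a lower number here means that less compound is needed, a higher number that more compound is needed for the effect), a limit of the assay.
Compound 2 `C=C[C@@](C)(/C=C/c1ccc(OS(=O)(=O)c2ccc(C)cc2)cc1)CCC=C(C)C`: > 43400 nM, likewise a limit.
Compound 3 `COc1ccc(/C=C/[C@@](C)(/C=C/c2ccc(O)c(/C=C/C(C)=O)c2)CCC=C(C)C)cc1`: > 43400 nM, likewise a limit.

Compound 1 thus stands at the limit of this assay, and so do the other two measured compounds: the limit of > 43400 nM in this assay, at which 3 of the 3 values shown sit. For the measured compounds named here, the one single-point change that was measured, a step that the two limits leave unreadable from compound 1 to compound 2, gives no readable size or direction. Compound 4 `C=C[C@@](C)(/C=C/c1ccc(-c2ccc(F)cc2)cc1)CCC=C(C)C` differs from compound 1 by 4-fluorophenyl in place of ((trifluoromethyl)sulfonyl)oxy on an aromatic carbon. Going by the values given here, no measured step touches a 4-fluorophenyl group, so nothing read from the data points either way. Compound 4 is therefore expected to sit near the same limit, with an estimated 40000 nM (from 10000 nM to 100000 nM). The expected step of an at least 1.0-fold lower number from compound 1 to compound 4 (0.03 log units; that floor lies within the scatter) is estimated to lie within the usual scatter.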

Compound 4, half-maximal effective concentration: > 43400 nM
Compound 4 ended at the assay's limit; the forecaster's own chance of this, stated with the estimate: 70%; at least 1.0-fold (0.03 log units) between middle value and limit.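

Compound 1 and compound 4 both stand at a limit of the assay, so no step between them can be read: the limit of > 43400 nM in this assay, at which 4 of the 4 values shown sit.

The compounds shown leave open which change to the shared core, if any, would give a readable value in this assay.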